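Sulfinyl in Place of Heptyloxy: Expectation for Compound 4

This account rests on a few compounds, and the source may have more. Where it says the series, first, only, none or still open, it means among the compounds named here.

Three compounds have been measured in an assay on microsomes from liver for inhibition of sterol O-acyltransferase 1 (Rattus norvegicus); a lower number here means a stronger inhibitor, a higher number a weaker inhibitor:

- compound 1 `CCCCCCOc1cc(-c2ccccc2)c(-c2ccccc2)nn1`: 72000 nM
- compound 2 `CCCCCCCOc1cc(-c2ccccc2)c(-c2ccccc2)nn1`: 58000 nM
- compound 3 `CCCCCCCCCOc1cc(-c2ccccc2)c(-c2ccccc2)nn1`: 180000 nM

Compound 2 gives the lowest number of the three; the step of a 1.2-fold lower number from compound 1 to compound 2 (0.09 log units; within the scatter) lies within the scatter, while the step of a 3.1-fold higher number from compound 2 to compound 3 (0.49 log units; beyond the scatter) lies beyond it. Compound 4 `CCCCCC[S+]([O-])c1cc(-c2ccccc2)c(-c2ccccc2)nn1` differs from compound 2 by a group of 8 heavy atoms (6 carbon, 1 oxygen, 1 sulfur; no ring) in place of a group of 8 heavy atoms (7 carbon, 1 oxygen; no ring), on an aromatic carbon. The measured steps all concern chain length only, for example a 2.5-fold higher number from compound 1 to compound 3 (0.40 log units; beyond the scatter); none bears on exchanging the oxygen link for a sulfur-bearing one, so little can be drawn from them. Compound 4 is therefore estimated at 100000 nM, between 25000 nM and 400000 nM. The estimated step of a 1.7-fold higher number from compound 2 to compound 4 (0.24 log units; within the scatter) is expected to be modest and uncertain in direction.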

Compound 4, half-maximal inhibitory concentration: 75000 nM
Beside the measured number, compound 4's estimate is 1.3-fold (0.12 log units) above it, and the stated range covers the measured number.
By their numbers in this assay, from the lowest: compounds 2, 1 and 4 (each within the scatter of the next); then compound 3.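

In this assay, for the compounds shown here, exchanging heptyloxy for the sulfur-bearing group on this aromatic carbon, the first change to the link itself, stays within the scatter (a 1.3-fold higher number from compound 2 to compound 4 (0.11 log units; within the scatter)), and so does the comparison with the oxygen-linked chain of compound 1 (a 1.0-fold higher number from compound 1 to compound 4 (0.02 log units; within the scatter)). The position therefore accepts this sulfur-bearing link with no step beyond the scatter, which the chain-length steps could not show. Nothing available explains this result.

Going by these compounds, whether a thioether, a sulfone or an amine at this carbon would behave alike remains open. So does whether a longer chain on the sulfur-bearing link would raise the number as it did on the oxygen link (a 3.1-fold higher number from compound 2 to compound 3 (0.49 log units; beyond the scatter)).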